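The source may report more compounds than this note shows. Statements on the series, on what has been measured and on what is new or still open speak of the compounds shown alone.

Compound 1 `C/C(CN(C[C@H]1Cc2ccccc2CN1)[C@H]1CCCc2cccnc21)=C(\F)CN` sits second highest of the three numbers recorded in a functional assay on CCRF-CEM cells for antagonist activity at C-X-C chemokine receptor type 4 (Homo sapiens), read by calcium flux, with stated times of 25 min and 90 s (on this read-out lower numbers stand for stronger inhibition and higher numbers for weaker inhibition), where compound 1 gives 80 nM. Its nearest neighbour is compound 3 `FC1(F)CCC(NC/C=C\CN(C[C@H]2Cc3ccccc3CN2)[C@H]2CCCc3cccnc32)CC1`, which in this assay gives 98 nM, and the furthest is compound 2 `C/C(CN)=C(/F)CN(C[C@H]1Cc2ccccc2CN1)[C@H]1CCCc2cccnc21`, which in this assay gives 44 nM; both lie within the scatter of compound 1.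

Compound 4 `N[C@H]1CC[C@H](CN(C[C@H]2Cc3ccccc3CN2)[C@H]2CCCc3cccnc32)CC1` differs from compound 1 in one place: 4-aminocyclohexyl in place of 3-amino-2-fluoro-1-methylprop-1-en-1-yl on a saturated chain carbon bound to an amine nitrogen. Among the compounds with values here, the only measured step at this same position is a 1.8-fold lower number from compound 1 to compound 2 (0.26 log units; within the scatter), which swaps one fluorinated chain for another rather than exchanging the chain for a ring, so it speaks to the present change only loosely. Compound 3 carries yet another group there and lands close to compound 1. Taken together, the three measured compounds show that different substituents on a saturated chain carbon bound to an amine nitrogen have so far given numbers within a narrow band, and nothing recorded here points to a move beyond the scatter in either direction.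

The expectation for compound 4 is therefore no change at the digits printed from compound 1 to compound 4 (within the scatter), an estimate of 80 nM in this assay, with a plausible range from 25 nM to 250 nM.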

Compound 4, half-maximal inhibitory concentration: 280 nM
Estimate against measurement, compound 4: 3.5-fold (0.54 log units) below; the measured number lies above the stated range.
By their numbers in this assay, from the lowest: compounds 2, 1 and 3 (each within the scatter of the next, the first and the last beyond it); then compound 4.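

In this assay, within the data shown here, the change on a saturated chain carbon bound to an amine nitrogen moves the number beyond the scatter for the first time: 4-aminocyclohexyl in place of 3-amino-2-fluoro-1-methylprop-1-en-1-yl gives a 3.5-fold higher number from compound 1 to compound 4 (0.54 log units; beyond the scatter) and, in place of 2-(aminomethyl)-1-fluoroprop-1-en-1-yl, gives a 6.4-fold higher number from compound 2 to compound 4 (0.80 log units; beyond the scatter) with the same count of hydrogen-bond donors and acceptors in the groups exchanged. So this position does not treat all amine-bearing groups alike, yet a simple contrast of ring against open chain does not hold, as the group in compound 3 also contains a ring and compound 3 gives 98 nM in this assay. Nothing available here explains why compound 4 gives the higher number.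

Compound 4 loses the double bond and the fluorine and gains a ring, all in one step, so the compounds shown cannot separate these changes. A saturated open chain ending in an amine, such as 4-aminobutyl, at the same place would help show whether the ring or the loss of the double bond and fluorine goes with the higher number.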